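The compounds below may be only part of what the source reports. "The series", "measured", "known", "first", "only" and "open" are said of these compounds alone.

Measured compounds:
- compound 1, `Cc1ccc(S(=O)(=O)NC(=O)n2ccc3cccnc32)cc1`: 20.3%
- compound 2, `O=C(NS(=O)(=O)c1ccccc1)n1ccc2cc(Br)cnc21`: 16.8%

Both compounds were tested in a functional assay on MCF7 cells (Homo sapiens) for antiproliferative activity, read by MTT assay, with a stated time of 24 h, tested at 10 uM; a higher number here means more inhibition at the concentration tested (going by the name of the read-out), a lower number less inhibition. Compound 1 gives 20.3% there, and compound 2 gives 16.8%. Compound 2 stands at the lower of these two numbers, but its nearest neighbour is compound 1, whose value lies only a little higher, and that gap is within the scatter of the method; the two are therefore not distinguishable on the data shown.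

The account now follows the step from compound 2 to compound 3, `Cc1ccc(S(=O)(=O)NC(=O)n2ccc3cc(Br)cnc32)cc1`, which has not yet been measured in this assay. The structural change is methyl in place of hydrogen on an aromatic carbon; cut one bond further out it reads phenyl to 4-methylphenyl, on an aromatic carbon of a six-membered aromatic ring of carbon only, para to a large group. Within the data shown here, no measured pair shows this change in isolation. The only point of reference is that compound 1 and compound 2, which differ in more than one place, sit within the scatter of each other, so no step beyond the scatter is expected in either direction. The step expected is a number 2.2 percentage points higher from compound 2 to compound 3 (within the scatter). Compound 3 is accordingly estimated to give about 19% in this assay, with a range from 7% to 32%.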

Compound 3, a percentage reported as inhibition, at one concentration (the size of the read-out at that concentration, not a potency): 28%
The estimate for compound 3 lay 9 percentage points below the measured number, and the stated range covers the measured number.
By their numbers in this assay, from the lowest: compounds 2, 1 and 3 (each within the scatter of the next, the first and the last beyond it).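

In this assay, methyl in place of hydrogen on an aromatic carbon, para to a large group, gives a number 11.2 percentage points higher from compound 2 to compound 3 (beyond the scatter). Among these compounds, this is the first change in a single place to be read at this position, and it shows that the phenyl to 4-methylphenyl change on the bromo-bearing core can move the read-out by more than the scatter, although only this one pair supports that. The second single change, the addition of a bromo group to the core, gives a number 7.7 percentage points higher from compound 1 to compound 3 (within the scatter), so this pair does not separate the effect of the bromo group from the scatter, and nothing in the data explains either step.

The compounds shown leave open whether a longer chain such as ethyl, a methoxy group or an amine at the same place would raise the number further or whether the step is particular to methyl. Among the compounds shown here, they also leave open whether methyl gives a similar step on the core without bromo, since they offer no pair for that comparison.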